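A few compounds are considered here, and "the series" means these few. Any claim that something is new, unique, unknown or untested is made for them only; others in the source may bear on it.

Measured compounds in a functional assay on HCT-116 cells (Homo sapiens) for antiproliferative activity, read by MTT assay, with a stated time of 72 h; on this read-out higher numbers stand for weaker inhibition and lower numbers for stronger inhibition:
- compound 1 `Cc1cccc(NC2=C/C(=N/NC(N)=S)C(=O)N=C2Nc2cccc(C)c2)c1`, with a value of 8650 nM
- compound 2 `NC(=S)N/N=C1/C=C(Nc2cccc(Cl)c2)C(Nc2cccc(Cl)c2)=NC1=O`, with a value of 3380 nM

Of the two measured compounds, compound 1 has the higher number in this assay; compound 2 stands at a lower number, and the gap between them lies beyond the usual scatter of this kind of measurement. Compound 1 is therefore the weaker of the two on the numbers shown.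

Compound 3 `Cc1cccc(NC2=C/C(=N/N=C(\N)SCc3ccccc3)C(=O)N=C2Nc2cccc(C)c2)c1` is the unmeasured compound that follows from compound 1 by a single change: a group of 11 heavy atoms (8 carbon, 2 nitrogen, 1 sulfur; one six-membered aromatic ring of carbon only) in place of a group of 4 heavy atoms (1 carbon, 2 nitrogen, 1 sulfur; no ring), on a double-bonded nitrogen. Among the measured compounds shown here, nothing among the measured compounds shows the effect of this particular exchange, since compound 2 differs from compound 1 in another part of the structure. The expectation for compound 3 in this assay can rest only on the value of compound 1 and on the size of the change itself, which replaces a small open-chain group by a larger one carrying a benzyl unit. A modest shift toward a lower number is expected for compound 3, with the step of a 1.7-fold lower number from compound 1 to compound 3 (0.24 log units; within the scatter), though a step in either direction within the scatter would not surprise. Compound 3 is estimated to give 5000 nM, within a range from 1500 nM to 20000 nM.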

Compound 3, half-maximal inhibitory concentration: 12900 nM
Estimate against measurement, compound 3: 2.6-fold (0.41 log units) below; the range from low to high includes it.
By their numbers in this assay, from the lowest: compound 2; then compounds 1 and 3 (each within the scatter of the next).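

In this assay, the exchange on the double-bonded nitrogen gives a 1.5-fold higher number from compound 1 to compound 3 (0.17 log units; within the scatter), the first step shown at this position, and the read-out does not separate the two groups. Thus, on this single pair, the group of 11 heavy atoms, with its six-membered aromatic ring of carbon only, 1 hydrogen-bond donor and 2 hydrogen-bond acceptors, reads the same within the scatter as the group of 4 heavy atoms, with no ring, 2 hydrogen-bond donors and 1 hydrogen-bond acceptor. Nothing measured here speaks to why these two groups read alike.

The compounds shown leave open whether a methyl group or a longer open chain in place of the benzyl unit would also read alike, and whether a chlorine or a methoxy group on that benzyl ring would move the number beyond the scatter. They also leave open whether the same exchange would give a step of similar size on compound 2, which differs from compound 1 in another part of the structure and has the lowest number of the three.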